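A few compounds are considered here, and "the series" means these few. Any claim that something is new, unique, unknown or untested is made for them only; others in the source may bear on it.

Measured in an ADME assay on MCF7 cells (Homo sapiens) for inhibition; on this read-out higher numbers stand for weaker inhibition and lower numbers for stronger inhibition:
Compound 1 `O=C(c1ccccc1)c1cc2c(F)c(F)c(-n3cnc4ccccc43)c(F)c2s1` gives > 25000 nM as a limit of the assay
Compound 2 `CC(C)(C)c1ccc(Sc2c(F)c(F)c3cc(C(=O)c4ccccc4)sc3c2F)cc1` gives > 25000 nM as a limit of the assay

Compound 2 stands at > 25000 nM, which is a limit and not a number. That is all that can be said of its place, and compound 1 offers only the same limit: the limit of > 25000 nM in this assay, at which 2 of the 2 values shown sit. Within the data shown here, no measured step shows what a change on the sulfur does.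

Compound 3 `O=C(CSc1c(F)c(F)c2cc(C(=O)c3ccccc3)sc2c1F)c1ccccc1` keeps the shared core and carries benzoylmethyl in place of 4-(tert-butyl)phenyl on a sulfur. With compound 2 at the limit of > 25000 nM as the nearest reference, no step beyond the scatter is expected in this assay. The estimated step is a number no higher from compound 2 to compound 3 (the limit leaves the size open), and any movement would more likely be towards stronger inhibition. Compound 3 is expected at 25000 nM, within an estimated range from 10000 nM to 50000 nM.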

Compound 3, half-maximal inhibitory concentration: > 50000 nM
Compound 3: only a limit was reported; the forecaster's own chance of this, stated with the estimate: 70%; middle value at least 2.0-fold (0.30 log units) from the limit.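

In this assay compound 3 gives > 50000 nM, which is a limit of the assay and not a number. Among these compounds, compound 1 and compound 2 also stand at limits, so no step to compound 3 can be read. The compounds shown leave open whether any change on the sulfur alters inhibition.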